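A few compounds are considered here, and "the series" means these few. Any claim that something is new, unique, unknown or untested is made for them only; others in the source may bear on it.

Going by the values given here, in an assay on isolated protein for inhibition of P-selectin glycoprotein ligand 1 (Homo sapiens), read by surface plasmon resonance, tested at 250 uM (a higher number here means more inhibition at the concentration tested (going by the name of the read-out), a lower number less inhibition), compound 2 `CC(C)(c1ccccc1)c1nc2c(C(F)(F)F)cccc2c(C(=O)O)c1O` gives 59%, the higher of two numbers so far, with compound 1 `CC(c1ccccc1)c1nc2c(C(F)(F)F)cccc2c(C(=O)O)c1O` at 50% nearest. Among the compounds with values here, the one step measured between them, a number 9 percentage points higher from compound 1 to compound 2 (within the scatter), stays within the scatter. The next compound, compound 3 `CCC(c1ccccc1)c1nc2c(C(F)(F)F)cccc2c(C(=O)O)c1O`, differs from compound 2 by 1-phenylpropyl in place of 1-methyl-1-phenylethyl on an aromatic carbon, a rearrangement of the same atoms. Within the data shown here, only that one step bears on it, and it was small, so the step to compound 3 is expected to be a number 4 percentage points lower from compound 2 to compound 3 (within the scatter), none beyond the scatter. In this assay compound 3 is therefore estimated to give 55%, expected between 40% and 70%.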

Compound 3, a percentage reported as inhibition, at one concentration (the size of the read-out at that concentration, not a potency): 55%
Compound 3: middle estimate and measured number agree at the digits printed, within the range that was stated.
By their numbers in this assay, from the lowest: compounds 1, 3 and 2 (each within the scatter of the next).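

Rearranging the same atoms, with 1-phenylpropyl in place of 1-methyl-1-phenylethyl, gives a number 4 percentage points lower from compound 2 to compound 3 (within the scatter) in this assay, while a methyl added further along the chain gives a number 5 percentage points higher from compound 1 to compound 3 (within the scatter). On this aromatic carbon next to the ring nitrogen, neither the shape of the side group nor the added methyl moves the number beyond the scatter, so these three side groups cannot be told apart here. Nothing available accounts for this result.

Still open, from the compounds shown here alone, is whether a longer chain such as 1-phenylbutyl, or an amine on the side chain, would shift the number beyond the scatter.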